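The compounds below may be only part of what the source reports. "The series", "measured", "known", "first", "only" and "open" are said of these compounds alone.

Compound 3 `CCCc1cn([C@H]2C[C@@H]3OP(=O)(O)OC[C@H]3O2)c(=O)[nH]c1=O` carries a propyl chain on the shared core. In a functional assay on L1210 cells (Mus musculus) (a higher number here means a weaker inhibitor, a lower number a stronger inhibitor), compound 3 gives > 500 ug/mL, which is a limit of the assay rather than a number. Compound 1 `CCc1cn([C@H]2C[C@@H]3OP(=O)(O)OC[C@H]3O2)c(=O)[nH]c1=O` gives > 500 ug/mL in this assay, also a limit. Compound 3 therefore sits at the limit of > 500 ug/mL in this assay, at which 2 of the 3 values shown sit. Compound 2 `CCCCCCCCc1cn([C@H]2C[C@@H]3OP(=O)(O)OC[C@H]3O2)c(=O)[nH]c1=O` gives 193 ug/mL in this assay. The two readable steps, an at least 2.5-fold higher number from compound 2 to compound 3 (0.41 log units; beyond the scatter) and an at least 2.5-fold lower number from compound 1 to compound 2 (0.41 log units; beyond the scatter), point the same way: within these three compounds the longer chain gives the lower number. Compound 4 `CCCCCc1cn([C@H]2C[C@@H]3OP(=O)(O)OC[C@H]3O2)c(=O)[nH]c1=O` differs from compound 3 by ethyl in place of hydrogen on a saturated chain carbon, three bonds along the chain from an aromatic carbon. Its chain is shorter than that of compound 2, so a number between the limit and that of compound 2 is expected. Compound 4 is estimated at 400 ug/mL, between 150 ug/mL and 900 ug/mL, an expected step of an at least 1.2-fold lower number from compound 3 to compound 4 (0.09 log units; that floor lies within the scatter).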

Compound 4, concentration for 50% inhibition: > 500 ug/mL
Compound 4 ended at the assay's limit (the forecaster's own chance of this, stated with the estimate: 45%); at least 1.2-fold (0.09 log units) between middle value and limit.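

Compound 4, with its pentyl chain, stays at a limit of the assay, so going from propyl to pentyl brings no readable change in this assay, and the steps to compound 4 from compound 3 and from compound 1 cannot be read. Compound 2 alone now stands clear of that limit, with an at least 2.5-fold higher number from compound 2 to compound 4 (0.41 log units; beyond the scatter). The readings gather at one point: the limit of > 500 ug/mL in this assay, at which 3 of the 4 values shown sit.

As far as these compounds go, the chain length at which the number first leaves the limit stays open. So does the outcome with a chain longer than that of compound 2, or with an amine in place of the chain.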